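Swapping the Dibromophenyl Arm for a Fluoro-Methoxyphenyl

A few compounds are considered here, and "the series" means these few. Any claim that something is new, unique, unknown or untested is made for them only; others in the source may bear on it.

Of the compounds shown here, three sharing one core have been tested in an ADME assay on microsomes from liver (Rattus norvegicus) for metabolic stability, read by LC-MS, using NADPH, at 37 degrees C; on this read-out higher numbers stand for a longer-lived compound and lower numbers for a shorter-lived compound. Compound 1 `Cc1ccccc1-c1nc(CN2CCC(C(=O)NCCCN3CCC(C(C)C)CC3)CC2)c(C)o1` gives 0.147 h in this assay. Compound 2 `Cc1ccccc1-c1nc(CN2CCC(C(=O)NCCCN3[C@H](C)CCC[C@@H]3C)CC2)c(C)o1` reaches only a limit of this assay, > 0.5 h. Compound 3 `Cc1oc(-c2c(Br)cccc2Br)nc1CN1CCC(C(=O)NCCCN2C[C@H](C)C[C@H](C)C2)CC1` gives 0.035 h in this assay, the lower of the two numbers, below compound 1.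

Going by the values given here, the one measured step, an at least 3.4-fold higher number from compound 1 to compound 2 (0.53 log units; beyond the scatter), alters the amine end of the chain rather than the aryl group, so it does not bear on the change at hand. Compound 4 `COc1cccc(F)c1-c1nc(CN2CCC(C(=O)NCCCN3C[C@H](C)C[C@H](C)C3)CC2)c(C)o1` differs from compound 3 by 2-fluoro-6-methoxyphenyl in place of 2,6-dibromophenyl on an aromatic carbon. Among the compounds with values here, with no measured step touching this part of the molecule, no shift beyond the scatter is expected; the estimated step is a 1.7-fold higher number from compound 3 to compound 4 (0.23 log units; within the scatter). Compound 4 is therefore expected to give about 0.06 h, within a range from 0.02 h to 0.2 h.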

Compound 4, half-life: 0.143 h
For compound 4 the middle estimate is 2.4-fold (0.38 log units) below the measured one, within the range that was stated.
By their numbers in this assay, from the lowest: compound 3; then compounds 4 and 1 (each within the scatter of the next). At a limit, above all of these: compound 2.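

Replacing 2,6-dibromophenyl with 2-fluoro-6-methoxyphenyl gives a 4.1-fold higher number from compound 3 to compound 4 (0.61 log units; beyond the scatter) in this assay. Going by these compounds alone, the earlier measured step changed only the amine end of the chain, so this is the first sign that the aryl group on the shared core also moves the half-life. Nothing in the data at hand explains this shift.

The change swaps both bromines at once, so the fluorine and methoxy contributions remain unseparated. A 2,6-difluorophenyl or 2,6-dimethoxyphenyl group at this position would be needed to tell them apart.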